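Chloro in place of hydrogen: cytotoxicity notes on the series

This account rests on a few compounds, and the source may have more. Where it says the series, first, only, none or still open, it means among the compounds named here.

Measured so far:
compound 1, `COc1ccccc1S(=O)(=O)/C=C/c1ccccn1`: 100%
compound 2, `COc1ccccc1S(=O)(=O)/C=C/c1ncccc1Cl`: 100%
compound 3, `COc1cccc(S(=O)(=O)/C=C/c2ccccn2)c1`: 100%

In an ADME assay on BV-2 cells (Mus musculus) for cytotoxicity, with a stated time of 24 h, tested at 10 uM (on this read-out lower numbers stand for a stronger effect and higher numbers for a weaker effect at the one concentration tested), compound 1 gives 100%, compound 2 gives 100% and compound 3 gives 100%. Among the compounds with values here, the one step with a shared core is no change at the digits printed from compound 1 to compound 2 (within the scatter), the change being (chloro in place of hydrogen on an aromatic carbon). Compound 3 differs from compound 1 in more than one place; the difference between the two cores is not broken down here, and the two values show no difference within the scatter.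

Compound 4, `COc1cccc(S(=O)(=O)/C=C/c2ccc(Cl)cn2)c1`, is not yet measured in this assay. It differs from compound 3 by chloro in place of hydrogen on an aromatic carbon. This is the same kind of change as that from compound 1 to compound 2, but the place is not the same: in compound 2 the chloro stands ortho to a large group, in compound 4 para to a large group. The step is expected to be no change at the digits printed from compound 3 to compound 4 (within the scatter), because the step of no change at the digits printed from compound 1 to compound 2 (within the scatter) showed no change. Compound 4 is estimated at 100%, between 90% and 108%.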

Compound 4, a percentage reported as activity, at one concentration (the size of the read-out at that concentration, not a potency): 100%
Beside the measured number, compound 4's estimate shows no gap at the digits printed, within the range that was stated.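

In this assay, chloro in place of hydrogen on an aromatic carbon gives no change at the digits printed from compound 3 to compound 4 (within the scatter), so the change reads the same on the second core as on the first. Across these two pairs, the change carries from one core to the other without a difference between the steps: the same change on two cores in this assay, no change at the digits printed (within the scatter) from compound 1 to compound 2 and no change at the digits printed (within the scatter) from compound 3 to compound 4, 0 percentage points apart, within the scatter of two such steps. This does not show that the change would behave alike on any other core or at any other concentration, and because the chloro in compound 4 stands para to a large group while that in compound 2 stands elsewhere, the two pairs do not separate the effect of core from that of place.

The compounds shown leave open whether a group other than chloro on the same ring, such as an amine, a carboxylic acid or a longer chain, would give a read-out away from the level shared by these four compounds. They also leave open whether chloro in other places on the ring would read the same on either core.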